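Acetyl to Propanoyl on a Pyrrole-Bearing Lactone

This account rests on a few compounds, and the source may have more. Where it says the series, first, only, none or still open, it means among the compounds named here.

Measured compounds:
- compound 1 `C#CC[C@@H]1C[C@H](n2cccc2C(C)=O)C(=O)O1`: 8.03%
- compound 2 `C#CC[C@H]1C[C@H](n2cccc2C(C)=O)C(=O)O1`: 9.04%

Both compounds were tested in a functional assay on N2a cells (Mus musculus), with a stated time of 48 h, tested at 0.01 uM; on this read-out lower numbers stand for a weaker effect and higher numbers for a stronger effect at the one concentration tested. Compound 1 gives 8.03%, and compound 2 gives 9.04%. Compound 1 holds the lower of the two numbers, but the step of a number 1 percentage points higher from compound 1 to compound 2 (within the scatter) lies within the scatter, so the two cannot be told apart on this read-out. The two compounds share every atom and bond and differ only in how one stereocentre is drawn, as shown by the fact that compounds 1 and 2 differ only in the configuration as drawn.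

For the measured compounds named here, the unmeasured compound 3 `C#CC[C@@H]1C[C@H](n2cccc2C(=O)CC)C(=O)O1` keeps the core of compound 1 and its drawn configuration; the only change is methyl in place of hydrogen on a saturated chain carbon bound to a carbonyl carbon. No measured step touches this part of the molecule: the single step shown concerns configuration, not the acetyl group, and it was within the scatter. There is therefore no ground to expect a change beyond the scatter in this assay, and the step of a number 0.5 percentage points higher from compound 1 to compound 3 (within the scatter) is estimated to stay small. Compound 3 is expected to give about 8.5%, in a range from 0% to 20%.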

Compound 3, a percentage reported as activity, at one concentration (the size of the read-out at that concentration, not a potency): 11.6%
For compound 3 the middle estimate is 3.1 percentage points below the measured one; low and high end bracket the measured number.
By their numbers in this assay, from the lowest: compounds 1, 2 and 3 (each within the scatter of the next).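

For the compounds shown here, this is the first look at the acyl group on the pyrrole rather than at the drawn configuration. In this assay, going from acetyl to propanoyl, with methyl in place of hydrogen on a saturated chain carbon bound to a carbonyl carbon, gives a number 3.6 percentage points higher from compound 1 to compound 3 (within the scatter). This position therefore takes the extra methyl with no effect that can be told apart from the usual scatter at the one concentration tested, although a single small group cannot show how far that tolerance extends. Nothing given here bears on a cause for the size of this step.

The compounds shown leave open whether a larger change at the same place, such as a longer chain like butanoyl, a phenyl group or a carboxylic acid in place of the acetyl group, would move the number beyond the scatter. They also leave open whether propanoyl behaves the same way with the other drawn configuration of the stereocentre, and whether a test at other concentrations would separate these compounds, since one concentration gives the size of the read-out and not a potency.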